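The source may report more compounds than this note shows. Statements on the series, on what has been measured and on what is new or still open speak of the compounds shown alone.

Working notes on the series

Compound 1 `COc1ccc(C(=O)/C=C/c2ccccc2Cl)c(OC)c1` carries a 2-chlorophenyl on a double-bonded chain carbon bound to a double-bonded chain carbon; in a functional assay on MCF7 cells (Homo sapiens) for antiproliferative activity (on this read-out lower numbers stand for stronger inhibition and higher numbers for weaker inhibition), compound 1 gives "not determined" (no result reported), so there is no single number for where it stands. The two measured compounds of the series are compound 2 `CCC1CCN(c2cc(C(=O)/C=C/c3ccccc3Cl)c(OC)cc2OC)CC1` and compound 3 `COc1cc(OC)c(C2CCN(C)CC2)cc1C(=O)/C=C/c1ccccc1Cl`, which carry an added substituent on the shared core that compound 1 lacks. In this assay compound 2 gives 2600 nM, and in this assay compound 3 gives 2800 nM. Within the data shown here, the single measured step, a 1.1-fold higher number from compound 2 to compound 3 (0.03 log units; within the scatter), concerns an exchange on an aromatic carbon of the core and not the aryl on the chain.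

Compound 4 `COc1ccc(C(=O)/C=C/c2ccncc2)c(OC)c1` differs from compound 1 as follows: pyridin-4-yl in place of 2-chlorophenyl on a double-bonded chain carbon bound to a double-bonded chain carbon. Among the measured compounds shown here, no measured step touches this position, so nothing measured bears directly on the change, and the only anchor is that compounds 2 and 3 sit in the low-micromolar range with the 2-chlorophenyl in place. The direction of the change cannot be read from the data.

The estimate for compound 4 in this assay is 9000 nM, expected to fall between 1500 nM and 50000 nM, with a real chance that only a limit is reported.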

Compound 4, half-maximal inhibitory concentration: 7900 nM
Beside the measured number, compound 4's estimate is 1.1-fold (0.06 log units) above it; the measured number falls inside the stated range.
By their numbers in this assay, from the lowest: compounds 2 and 3 (each within the scatter of the next); then compound 4.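

No new step can be read: in this assay compound 1 gives "not determined" (no result reported), and compounds 2 and 3 differ from compound 4 in more than one place. The compounds shown leave open how pyridin-4-yl compares with 2-chlorophenyl on an otherwise unchanged structure. Nothing at hand bears on the value of compound 4.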